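Side-chain ester in place of ether: notes on compound 4

This account rests on a few compounds, and the source may have more. Where it says the series, first, only, none or still open, it means among the compounds named here.

Measured so far in a functional assay on DU-145 cells (Homo sapiens) for cytotoxicity, read by MTT assay; a lower number here means a stronger inhibitor, a higher number a weaker inhibitor: compound 1 `CCC(O)CO[C@H](CC=C(C)C)C1=CC(=O)c2c(O)ccc(O)c2C1=O` gives 16400 nM; compound 2 `CCCC(CC(=O)O[C@H](CC=C(C)C)C1=CC(=O)c2c(O)ccc(O)c2C1=O)OC(C)=O` gives 55700 nM; compound 3 `CCC(CO[C@H](CC=C(C)C)C1=CC(=O)c2c(O)ccc(O)c2C1=O)OC(C)=O` gives 25400 nM.

Compound 1 holds the lowest number of the three; compound 3 lies within the scatter of it, while compound 2 sits beyond the scatter with the higher number. Among the measured compounds shown here, the only single-site step, a 1.5-fold higher number from compound 1 to compound 3 (0.19 log units; within the scatter), is within the scatter. Compound 4 `CCC(C)(O)CC(=O)O[C@H](CC=C(C)C)C1=CC(=O)c2c(O)ccc(O)c2C1=O` differs from compound 1 as follows: (2-hydroxy-2-methylbutyl)carbonyl in place of 2-hydroxybutyl on an oxygen on a saturated carbon. For the measured compounds named here, no measured step covers this change directly. Going by the values given here, compound 2, the one other compound carrying a carbonyl on that oxygen, shows a higher number than compound 1, and compound 3 shows that altering the side-chain hydroxyl moves little. A modestly higher number is therefore expected in this assay, a 1.8-fold higher number from compound 1 to compound 4 (0.26 log units; within the scatter). For compound 4 the estimate is 30000 nM, in the range 12000 nM to 80000 nM.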

Compound 4, half-maximal inhibitory concentration: 16000 nM
Compound 4: middle estimate off by 1.9-fold (0.27 log units), on the high side; low and high end bracket the measured number.
By their numbers in this assay, from the lowest: compounds 4, 1 and 3 (each within the scatter of the next); then compound 2.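

The carbonyl on that oxygen does not by itself set the number in this assay: the (2-hydroxy-2-methylbutyl)carbonyl group reads level with 2-hydroxybutyl (a 1.0-fold lower number from compound 1 to compound 4 (0.01 log units; within the scatter)) and with 2-acetoxybutyl (a 1.6-fold lower number from compound 3 to compound 4 (0.20 log units; within the scatter)). What separates compound 2 lies in the group on the saturated chain carbon bound to a carbonyl carbon, where 1-hydroxy-1-methylpropyl in place of 1-acetoxybutyl gives a step beyond the scatter (a 3.5-fold lower number from compound 2 to compound 4 (0.54 log units; beyond the scatter)). No measured evidence accounts for this. Hydroxyl and chain differ together in that step, so their shares remain unseparated. An amine in place of the hydroxyl remains an open case.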